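This account rests on a few compounds, and the source may have more. Where it says the series, first, only, none or still open, it means among the compounds named here.

Measured so far:
compound 1, `CCC[C@@H](NC(=O)c1nccs1)c1cnc(Nc2ccc(C)nc2)c(Cl)c1`, 8.2 nM
compound 2, `CCCC[C@@H](NC(=O)c1nccs1)c1cnc(Nc2ccc(C)nc2)c(Cl)c1`, 30.9 nM
compound 3, `Cc1ccc(Nc2ncc([C@@H](NC(=O)c3nccs3)C(C)C)cc2Cl)cn1`, 1060 nM

In a functional assay on HEK293 cells for negative allosteric modulation of metabotropic glutamate receptor 5 (Homo sapiens), read by HTRF and inositol phosphate accumulation (a higher number here means a weaker inhibitor, a lower number a stronger inhibitor), compound 1 gives 8.2 nM and compound 2 gives 30.9 nM; the only single change among these three, a 3.8-fold higher number from compound 1 to compound 2 (0.58 log units; beyond the scatter), is a modest weakening. Compound 3, with a branched group instead of a straight chain, stands highest of the three numbers, far from compound 2 and further still from compound 1.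

Compound 4, `Cc1ccc(Nc2ncc([C@H](NC(=O)c3nccs3)C(C)C)cc2Cl)cn1`, differs from compound 3 only as follows: the two compounds have the same atoms and bonds and differ only in configuration as drawn: 1 of 1 stereo elements differ; a stereocentre at a saturated chain carbon is drawn S in compound 3 and R in compound 4. Among the compounds with values here, no measured pair differs only in configuration, so none of the steps seen so far bears on this change directly. All that the numbers show is that compound 3, drawn in one configuration, is the weakest by a wide margin; the opposite configuration could therefore be either much stronger or similarly weak, and that gives a wide range. The estimate is a step of a 7.1-fold lower number from compound 3 to compound 4 (0.85 log units; beyond the scatter) toward stronger inhibition, with compound 4 expected at 150 nM, between 10 nM and 2000 nM.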

Compound 4, half-maximal inhibitory concentration: 7.5 nM
Compound 4: the middle estimate sits 20-fold (1.30 log units) above what was measured; the whole stated range lies above it.
By their numbers in this assay, from the lowest: compounds 4 and 1 (each within the scatter of the next); then compound 2; then compound 3.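

In this assay, configuration alone carries a 140-fold lower number from compound 3 to compound 4 (2.15 log units; beyond the scatter), so the drawn stereocentre at this saturated chain carbon matters greatly, and the gap can be assigned to it because nothing else changes: the fact that compounds 3 and 4 differ only in the configuration as drawn

With the isopropyl group on that carbon, the two straight chains can now be compared: isopropyl in place of propyl gives a 1.1-fold lower number from compound 1 to compound 4 (0.04 log units; within the scatter), and isopropyl in place of butyl gives a 4.1-fold lower number from compound 2 to compound 4 (0.61 log units; beyond the scatter). Branching as such therefore does not bring the poor result of compound 3, which goes against any reading of branched groups as weak at this carbon.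

From the compounds shown here alone, whether reversing the stereocentre would matter as much with a propyl or butyl chain remains open. So does how a cyclopropyl or tert-butyl group would behave on this carbon.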